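A Methoxy Group on the Benzoyl Ring of Compound 3

This account rests on a few compounds, and the source may have more. Where it says the series, first, only, none or still open, it means among the compounds named here.

Of the compounds shown here, three sharing one core have been tested in a functional assay on A549 cells (Homo sapiens) for cytotoxicity, read by MTT assay, with a stated time of 48 h; on this read-out lower numbers stand for stronger inhibition and higher numbers for weaker inhibition. Compound 3 `COc1cc(-c2nnc3n2NC(c2ccco2)C(C(=O)c2ccccc2)S3)cc(OC)c1OC` gives 33400 nM. Compound 1 `COc1cc(-c2nnc3n2NC(c2ccco2)C(C(=O)c2ccccc2C)S3)cc(OC)c1OC` gives 80000 nM, and compound 2 `COc1cc(-c2nnc3n2NC(c2ccco2)C(C(=O)c2ccc(Br)cc2)S3)cc(OC)c1OC` gives 42100 nM. The step of a 2.4-fold lower number from compound 1 to compound 3 (0.38 log units; beyond the scatter) is modest, while a 1.3-fold lower number from compound 2 to compound 3 (0.10 log units; within the scatter) lies within the scatter. Compound 4 `COc1ccc(C(=O)C2Sc3nnc(-c4cc(OC)c(OC)c(OC)c4)n3NC2c2ccco2)cc1` carries methoxy in place of hydrogen on an aromatic carbon. The two changes already seen on the same benzoyl ring, a 2.4-fold lower number from compound 1 to compound 3 (0.38 log units; beyond the scatter) and a 1.3-fold lower number from compound 2 to compound 3 (0.10 log units; within the scatter), were small, so a new substituent on that ring is expected to move the number little. Compound 4 is therefore estimated at 32000 nM, with a range from 13000 nM to 80000 nM, a step of a 1.0-fold lower number from compound 3 to compound 4 (0.02 log units; within the scatter) expected to stay within the scatter.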

Compound 4, half-maximal inhibitory concentration: > 100000 nM
Compound 4: only a limit was reported; the forecaster's own chance of this, stated with the estimate: 10%; middle value at least 3.1-fold (0.49 log units) away from the limit.
By their numbers in this assay, from the lowest: compounds 3, 2 and 1 (each within the scatter of the next, the first and the last beyond it). At a limit, above all of these: compound 4.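

Hydrogen and bromo at this ring carbon, para to a large group, read within the scatter of each other, so this position looked undemanding, yet methoxy there gives an at least 2.9-fold higher number from compound 3 to compound 4 (0.47 log units; beyond the scatter) and an at least 2.3-fold higher number from compound 2 to compound 4 (0.37 log units; beyond the scatter). The third comparison gives an at least 1.2-fold higher number from compound 1 to compound 4 (0.09 log units; that floor lies within the scatter), so those two compounds cannot be put in order. For compound 4 the reading is a limit, not a number: the limit of > 100000 nM in this assay, at which 1 of the 4 values shown sits.

As far as these compounds go, how far compound 4 really sits beyond that limit stays open. So does whether a hydroxyl group or an amine at the same carbon would read like methoxy or like hydrogen and bromo.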